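This account rests on a few compounds, and the source may have more. Where it says the series, first, only, none or still open, it means among the compounds named here.

Measured so far:
- compound 1, `C[C@@H](NC(=O)c1ccc(C#Cc2ccccc2F)cn1)C(C)(C)O`, in a functional assay on HEK293 cells for positive allosteric modulation of metabotropic glutamate receptor 5 (Rattus norvegicus), read by fluorescence and calcium flux (on this read-out lower numbers stand for smaller maximal responses and higher numbers for larger maximal responses), gives 60%
- compound 2, `C[C@@H](NC(=O)c1ccc(C#CC2CCCC2)cn1)C(C)(C)O`, in this assay gives 63.7%

Compound 1 stands at the lowest of these two numbers, with compound 2 nearest; the two lie within the scatter of each other, so no order between them can be read from this pair.

The new compound is compound 3, `C[C@@H](NC(=O)c1ccc(C#Cc2ccc(F)cn2)cn1)C(C)(C)O`. It keeps the shared core of compound 1 and changes one place: 5-fluoropyridin-2-yl in place of 2-fluorophenyl on a triple-bonded carbon.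

Within the data shown here, only one measured step bears on this position, the one from compound 1 to compound 2, where a cyclopentyl replaced the 2-fluorophenyl on the triple-bonded carbon and gave a number 3.7 percentage points higher from compound 1 to compound 2 (within the scatter). That exchange, although it swaps a ring of one kind for a quite different one, left the maximal response where it was. Among the measured compounds shown here, no measured step shows a 5-fluoropyridin-2-yl at this place, so the expectation rests on that single step alone. On this basis no step beyond the scatter is expected in this assay, in either direction.

Compound 3 is therefore estimated at 60%, within a range of 45% to 76%, which is expected to mean a step of no change at the digits printed from compound 1 to compound 3 (within the scatter).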

Compound 3, largest response reached (reported as efficacy), in percent of the reference or control that the assay uses: 64.6%
Beside the measured number, compound 3's estimate is 4.6 percentage points below it; the measured number falls inside the stated range.
By their numbers in this assay, from the lowest: compounds 1, 2 and 3 (each within the scatter of the next).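

In this assay, placing 5-fluoropyridin-2-yl on the triple-bonded carbon in place of 2-fluorophenyl gives a number 4.6 percentage points higher from compound 1 to compound 3 (within the scatter) and so does not separate the two aromatic rings, even though the entering ring carries a ring nitrogen and counts one hydrogen-bond acceptor where the leaving ring counts none. Set against cyclopentyl, the same group gives a number 0.9 percentage points higher from compound 2 to compound 3 (within the scatter) and so does not separate these two either, which means that all three groups now seen at this position, two aromatic rings and one cyclopentyl, give maximal responses within the scatter of one another. Nothing available explains why the largest response stays put across these exchanges.

These three compounds leave open whether any group on the triple-bonded carbon can move the maximal response beyond the scatter, in either direction. A primary amine, a carboxylic acid or a longer straight carbon chain at this place could test how far this tolerance reaches, and an unsubstituted pyridin-2-yl could show whether the fluorine on the ring plays any part.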